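The compounds below may be only part of what the source reports. "The series", "measured", "known", "first", "only" and "open" are said of these compounds alone.

In a functional assay on HeLa cells (Homo sapiens) for cytotoxicity, read by MTT assay, with a stated time of 48 h (on this read-out lower numbers stand for stronger inhibition and higher numbers for weaker inhibition), compound 2 `C=C1CCC[C@]2(C)CCC(c3cn(-c4cccc([N+](=O)[O-])c4)nn3)=CC[C@@]12C` stands at 31900 nM and compound 1 `C=C1CCC[C@]2(C)CCC(c3cn(-c4ccc(OC)cc4)nn3)=CC[C@@]12C` stands at 43600 nM on the same read-out; the two numbers lie within the scatter of each other. The move to compound 3 `C=C1CCC[C@]2(C)CCC(c3cn(-c4cccc(OC)c4)nn3)=CC[C@@]12C` is methoxy in place of nitro on an aromatic carbon and amounts to methoxy in place of nitro on an aromatic carbon, meta to a large group. For the measured compounds named here, the one measured step bearing on it is a 1.4-fold lower number from compound 1 to compound 2 (0.14 log units; within the scatter) and it also exchanges these two groups. No step beyond the scatter is therefore expected in this assay for this change. The estimated step is a 1.2-fold higher number from compound 2 to compound 3 (0.08 log units; within the scatter) and remains an expectation only. Compound 3 is expected at 38000 nM with an estimated range from 20000 nM to 70000 nM at this stage.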

Compound 3, half-maximal inhibitory concentration: 27900 nM
Estimate against measurement, compound 3: 1.4-fold (0.13 log units) above, within the range that was stated.
By their numbers in this assay, from the lowest: compounds 3, 2 and 1 (each within the scatter of the next).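

In this assay, methoxy in place of nitro, meta to a large group, gives a 1.1-fold lower number from compound 2 to compound 3 (0.06 log units; within the scatter), so the exchange is now read directly at this one place and stays within the scatter. 3-Methoxyphenyl in place of 4-methoxyphenyl gives a 1.6-fold lower number from compound 1 to compound 3 (0.19 log units; within the scatter), so these two placings of methoxy are not told apart on this read-out. Nothing at hand bears on the reason for either step. Open, as far as these compounds go, is whether an amine or a carboxylic acid at this place would give a step beyond the scatter.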